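From 4-ethoxyphenyl to 1H-indol-6-yl on a shared core

A few compounds are considered here, and "the series" means these few. Any claim that something is new, unique, unknown or untested is made for them only; others in the source may bear on it.

Compound 1 `COc1ccc(-c2cncnc2-c2cc(OC)c(OC)c(OC)c2)cc1F`: 500 nM
Compound 2 `COc1cc(-c2ncncc2-c2ccc(SC)cc2)cc(OC)c1OC`: 220 nM
Compound 3 `CCOc1ccc(-c2cncnc2-c2cc(OC)c(OC)c(OC)c2)cc1`: 250 nM

All three were tested in a functional assay on HeLa cells (Homo sapiens) for antiproliferative activity, read by CCK-8 assay, with a stated time of 72 h; on this read-out higher numbers stand for weaker inhibition and lower numbers for stronger inhibition. Compound 3, at 250 nM, lies within the scatter of both others, with a 2.0-fold lower number from compound 1 to compound 3 (0.30 log units; within the scatter) and a 1.1-fold higher number from compound 2 to compound 3 (0.06 log units; within the scatter). Compound 4 `COc1cc(-c2ncncc2-c2ccc3cc[nH]c3c2)cc(OC)c1OC` carries 1H-indol-6-yl in place of 4-ethoxyphenyl on an aromatic carbon. Within the data shown here, the closest evidence is the exchange of this same group among the measured compounds, and the one step beyond the scatter, a 2.3-fold lower number from compound 1 to compound 2 (0.36 log units; beyond the scatter), is modest. None of these exchanges brings in a five-membered aromatic ring, so the direction remains uncertain, and only a modest change is expected. The expected step is a 1.4-fold lower number from compound 3 to compound 4 (0.14 log units; within the scatter). Compound 4 is estimated at 180 nM, with an expected range of 50 nM to 600 nM.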

Compound 4, half-maximal inhibitory concentration: 770 nM
Compound 4: middle estimate off by 4.3-fold (0.63 log units), on the low side; measured number above the stated range.
By their numbers in this assay, from the lowest: compounds 2, 3, 1 and 4 (each within the scatter of the next, the first and the last beyond it).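

In this assay, the first five-membered aromatic ring at this aromatic carbon, brought in with 1H-indol-6-yl, weakens inhibition relative to two of the earlier groups (a 3.1-fold higher number from compound 3 to compound 4 (0.49 log units; beyond the scatter); a 3.5-fold higher number from compound 2 to compound 4 (0.54 log units; beyond the scatter)). Against 3-fluoro-4-methoxyphenyl, the same group makes no difference that can be told from the scatter (a 1.5-fold higher number from compound 1 to compound 4 (0.19 log units; within the scatter)). No measurement at hand bears on the reason for these steps. The compounds shown leave open whether 1-methyl-1H-indol-6-yl or 1H-indol-5-yl would give the same result at this position.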